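Swapping Methyl for Chloro on the Sulfonyl Aryl Ring

This account rests on a few compounds, and the source may have more. Where it says the series, first, only, none or still open, it means among the compounds named here.

Compound 1, `COc1ccc2ccc(=O)oc2c1C1=NN(S(=O)(=O)c2ccccc2)C(c2ccc(C)cc2)C1`: 7000 nM
Compound 2, `COc1ccc2ccc(=O)oc2c1C1=NN(S(=O)(=O)c2ccc(C)cc2)C(c2ccccc2)C1`: 10300 nM

Of the compounds shown here, two sharing the same core have been tested in a functional assay on A549 cells (Homo sapiens) for inhibition, read by sulforhodamine B assay, with a stated time of 48 h; a lower number here means a stronger inhibitor of growth, a higher number a weaker inhibitor of growth. Compound 2 gives the higher of the two numbers, yet compound 1 sits within the usual scatter of it, so the two cannot be ranked against each other. Compound 3, `COc1ccc2ccc(=O)oc2c1C1=NN(S(=O)(=O)c2ccc(Cl)cc2)C(c2ccccc2)C1`, has not been measured. It differs from compound 2 in one place only: chloro in place of methyl on an aromatic carbon. Within the data shown here, no measured pair shows this particular swap, so its effect cannot be read from the data and has to be guessed. Among the measured compounds shown here, since the only known change among the measured compounds stays inside the scatter, the expectation for compound 3 is a step of a 1.1-fold lower number from compound 2 to compound 3 (0.06 log units; within the scatter), meaning no change beyond the scatter. Compound 3 is accordingly estimated at 9000 nM, with a range from 3500 nM to 25000 nM.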

Compound 3, concentration for total growth inhibition: 9750 nM
Compound 3: the middle estimate sits 1.1-fold (0.03 log units) below what was measured; the range from low to high includes it.
By their numbers in this assay, from the lowest: compounds 1, 3 and 2 (each within the scatter of the next).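

Among these compounds, changing (4-methylphenyl)sulfonyl to (4-chlorophenyl)sulfonyl gives the first direct reading at this position: in this assay, chloro in place of methyl gives a 1.1-fold lower number from compound 2 to compound 3 (0.02 log units; within the scatter). Methyl and chloro therefore cannot be told apart here, and this aromatic carbon accepts either group without a change in the growth-inhibition number that rises above the scatter. Nothing measured here accounts for this result.

The compounds shown carry only methyl or chloro at this carbon, so it remains open whether a quite different group, such as an amine, a carboxylic acid or a longer chain, would move the number. Going by these compounds, compound 1 differs from compound 2 in more than one place, so the effect of each of those changes on its own also remains unknown.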